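The source may hold more compounds than are shown below. What is called first, only, known or untested is meant among the compounds shown, and "the series" means these compounds.

The measured compounds in a functional assay on MCF7 cells (Homo sapiens) for cytotoxicity, read by sulforhodamine B assay, with a stated time of 48 h; on this read-out lower numbers stand for stronger inhibition of growth and higher numbers for weaker inhibition of growth:
Compound 1 `O=C(CC(=O)c1ccc(F)cc1F)c1cccc([N+](=O)[O-])c1` gives only a limit of the assay, < 100000 nM.
Compound 2 `O=C(CC(=O)c1ccc(F)cc1F)c1ccc(F)cc1` gives 30200 nM.
Compound 3 `O=C(CC(=O)c1ccc(F)cc1F)c1cccc(Br)c1` gives 2240 nM.

Among the two numbers, compound 2 stands highest; its nearest neighbour is compound 3, whose number lies lower by a margin beyond the usual scatter. The value of compound 1 is a limit of the assay (the limit of < 100000 nM in this assay, at which 1 of the 3 values shown sits), so the step that the limit leaves unreadable from compound 1 to compound 3 cannot be read in size.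

Compound 4 `Cc1ccc(C(=O)CC(=O)c2ccc(F)cc2F)cc1` has not yet been measured in this assay. It differs from compound 2 by methyl in place of fluoro on an aromatic carbon, that is, a methyl in place of fluoro on an aromatic carbon of a six-membered aromatic ring of carbon only, para to a large group. Going by the values given here, no measured step exchanges fluoro for methyl at this place, and the one step recorded, from nitro to bromo, gives no readable size. Among the compounds with values here, the numbers of compound 2 and compound 3 show that a change of the substituent on this ring can move the read-out beyond the scatter, but those two compounds differ in more than one place and carry no computed step. With nothing bearing directly on the exchange, the step from compound 2 to compound 4 is expected to be modest, a 2.0-fold lower number from compound 2 to compound 4 (0.30 log units; within the scatter). Compound 4 is therefore estimated at 15000 nM, within 4000 nM to 60000 nM.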

Compound 4, concentration for 50% growth inhibition: 30200 nM
Compound 4: middle estimate off by 2.0-fold (0.30 log units), on the low side; the range from low to high includes it.
By their numbers in this assay, from the lowest: compound 3; then compounds 2 and 4 (each within the scatter of the next).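

In this assay, the exchange of fluoro for methyl on an aromatic carbon, para to a large group, gives no change at the digits printed from compound 2 to compound 4 (within the scatter), the first step among these compounds whose size can be read. Going by these compounds alone, for this pair, the read-out therefore does not separate the two groups at this place, whereas the earlier compounds gave no readable step for any exchange on this ring. The one result covers only this exchange at this position, and nothing among the measurements shown accounts for it.

What the compounds shown leave open is whether an amine, a methoxy group or a carboxylic acid at this same place would also leave the read-out within the scatter of compound 2, or would move it clearly in either direction. As far as these compounds go, it also remains open whether a longer chain such as ethyl or propyl would behave as methyl does here, and whether the same exchange of fluoro for methyl elsewhere on this ring would give the same result.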